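From phenyl to furan-3-yl on a shared core

This account rests on a few compounds, and the source may have more. Where it says the series, first, only, none or still open, it means among the compounds named here.

In an ADME assay on Vero cells (Chlorocebus sabaeus) for cytotoxicity, read by MTT assay, with a stated time of 96 h (a lower number here means that less compound is tolerated, a higher number that more compound is tolerated), compound 1 (`CC(=O)c1ccc2[nH]c(-c3ccccc3)nc2c1`) gives > 100000 nM as a limit, not a number. Compound 2 (`C/C(=N\NC(N)=S)c1ccc2[nH]c(-c3ccccc3)nc2c1`) gives > 100000 nM as a limit too. Compound 3 (`CC(=O)c1ccc2[nH]c(-c3ccoc3)nc2c1`) carries furan-3-yl in place of phenyl on an aromatic carbon of the shared core. Within the data shown here, the only measured step that bears on it is a step that the two limits leave unreadable from compound 1 to compound 2 and what it shows is the limit of > 100000 nM in this assay, at which 2 of the 2 values shown sit, alone. Resting on that unreadable step, the estimated a number no higher from compound 1 to compound 3 (the limit leaves the size open) is expected to stay within the scatter, in no stated direction. Compound 3 is expected near 100000 nM with an estimated range from 40000 nM to 250000 nM in this assay and may again give only a limit.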

Compound 3, half-maximal cytotoxic concentration: > 100000 nM
Compound 3 was reported as a limit (the forecaster's own chance of this, stated with the estimate: 75%); the middle value sits exactly at the limit.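

No step can be read from compound 1 to compound 3, because both are reported only as limits, not numbers: the limit of > 100000 nM in this assay, at which 3 of the 3 values shown sit. The compounds shown leave open whether furan-3-yl in place of phenyl changes the result in this assay.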